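Isobutyl in place of 4-chlorobenzyl at a cytotoxicity limit

The compounds below may be only part of what the source reports. "The series", "measured", "known", "first", "only" and "open" are said of these compounds alone.

Compound 1 `Cc1ccc2c(NCc3ccc(NC(=O)C4CCN(Cc5ccc(Cl)cc5)CC4)cc3)nc(N(C)C)nc2c1` was tested in a functional assay on SV5A8 cells (Homo sapiens) for cytotoxicity; on this read-out higher numbers stand for weaker inhibition and lower numbers for stronger inhibition. In this assay compound 1 gives only > 3180 nM, which is a limit of the assay and not a number; this is the limit (the limit of > 3180 nM in this assay, at which 1 of the 3 values shown sits). Two related compounds sit beside it. Compound 2 `Cc1ccc2c(NCc3ccc(NC(=O)C4CCN(Cc5ccccc5)CC4)cc3)nc(N3CCNC(CCO)C3)nc2c1` gives > 8420 nM in this assay, again a limit. Compound 3 `Cc1ccc2c(NCc3ccc(NC(=O)C4CCN(Cc5ccccc5)CC4)cc3)nc(N(C)CCN(C)C)nc2c1` gives > 8830 nM in this assay, also a limit. The step that the two limits leave unreadable from compound 2 to compound 3 is thus not readable, and it concerns a substituent on an aromatic carbon of the shared core, not the position changed here. Compound 1 therefore stands at a limit, as do the two other values shown, and none of the three is a number.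

Compound 4 `Cc1ccc2c(NCc3ccc(NC(=O)C4CCN(CC(C)C)CC4)cc3)nc(N(C)C)nc2c1` differs from compound 1 by isopropyl in place of 4-chlorophenyl on a saturated chain carbon bound to an amine nitrogen in a ring. Within the data shown here, no measured step in this set covers this position, so nothing here speaks for a gain or a loss in this assay. With every value in the set at a limit, compound 4 is expected to remain in the same region, and the step that the limit leaves unreadable from compound 1 to compound 4 is expected to be one that cannot be read beyond the scatter. Compound 4 is accordingly estimated at 6000 nM, with a range from 2000 nM to 25000 nM.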

Compound 4, half-maximal inhibitory concentration: > 10500 nM
Compound 4 gave a limit, no number (the forecaster's own chance of this, stated with the estimate: 75%); middle value at least 1.7-fold (0.24 log units) from the limit.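

Compound 4 gives > 10500 nM in this assay, which is a limit and not a number. Compound 1 also stands at a limit, so the step from compound 1 to compound 4 cannot be read. The compounds shown leave open whether isobutyl and 4-chlorobenzyl differ at all on this read-out.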